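The source may hold more compounds than are shown below. What is called first, only, known or untested is meant among the compounds shown, and "the series" means these compounds.

Measured in a functional assay on muscle tissue for agonist activity at histamine H2 receptor (Cavia porcellus); on this read-out lower numbers stand for lower potency and higher numbers for higher potency (the scale is a negative logarithm):
compound 1 `N=C(NCCCc1c[nH]cn1)NCCC(c1ccc(F)cc1)c1ccccn1` gives 7.94
compound 2 `N=C(NCCCc1c[nH]cn1)NCCC(c1ccc(C(F)(F)F)cc1)c1ccccn1` gives 7.23
compound 3 `N=C(NCCCc1c[nH]cn1)NCCC(c1cccc(F)c1)c1ccccn1` gives 7.79

Compound 1 stands highest of the three; compound 3 lies within the scatter of it (a number 0.15 log units lower from compound 1 to compound 3 (within the scatter)), compound 2 beyond it (a number 0.71 log units lower from compound 1 to compound 2 (beyond the scatter)). The third step, a number 0.56 log units higher from compound 2 to compound 3 (beyond the scatter), also concerns only the substituted phenyl.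

Compound 4 `N=C(NCCCc1c[nH]cn1)NCCC(c1ccc(F)cc1)c1cccnc1` changes a different place: pyridin-3-yl in place of pyridin-2-yl on a saturated chain carbon bound to an aromatic carbon and a saturated chain carbon. Going by the values given here, none of the measured steps touches the pyridyl, so none bears directly on this change; the measured steps only show that changes at this carbon can move this assay by a modest amount. A modest step is therefore expected, direction uncertain, estimated as a number 0.44 log units lower from compound 1 to compound 4 (beyond the scatter). For compound 4 the expected value is 7.5, range 6.8 to 8.2.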

Compound 4, negative logarithm of the half-maximal effective concentration: 7.91
Compound 4: middle estimate off by 0.41 log units, on the low side; the measured number falls inside the stated range.
By their numbers in this assay, from the lowest: compound 2; then compounds 3, 4 and 1 (each within the scatter of the next).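

In this assay, pyridin-3-yl in place of pyridin-2-yl on this saturated chain carbon stays within the scatter (a number 0.03 log units lower from compound 1 to compound 4 (within the scatter)). Going by these compounds alone, the earlier steps varied only the substituted phenyl, so this is the first reading on the pyridyl, and with 4-fluorophenyl held constant the two pyridyl isomers cannot be told apart. Nothing at hand offers an account of this result.

From the compounds shown here alone, whether pyridin-4-yl or an unsubstituted phenyl would hold the same level at this carbon remains open. Also open, going by these compounds, is whether pyridin-3-yl behaves the same alongside 4-(trifluoromethyl)phenyl.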